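Removing the aryl methyl from an inactive piperazine amide

This account rests on a few compounds, and the source may have more. Where it says the series, first, only, none or still open, it means among the compounds named here.

Compound 1, `Cc1ccc(N2CCN(C(=O)C3CCN(C(=O)c4ccc(S(C)(=O)=O)c([N+](=O)[O-])c4)CC3)CC2)cc1`: > 60000 nM
Compound 2, `CN(Cc1ccccc1F)C(=O)C1CCN(C(=O)c2ccc(S(C)(=O)=O)c([N+](=O)[O-])c2)CC1`: > 60000 nM
Compound 3, `CC1CCN(C(=O)CN(C)C(=O)c2ccc(S(C)(=O)=O)c([N+](=O)[O-])c2)CC1`: > 60000 nM

In an assay on isolated protein for inhibition of thyroid hormone receptor alpha (Homo sapiens), read by fluorescence polarization (on this read-out lower numbers stand for stronger inhibition and higher numbers for weaker inhibition), compound 1 returns only a limit, > 60000 nM. Compound 2 likewise gives a limit, > 60000 nM, in this assay. Compound 3 also ends at a limit, > 60000 nM. Compound 1 therefore stands, together with compounds 2 and 3, at the limit of > 60000 nM in this assay, at which 3 of the 3 values shown sit, and no number is known for it.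

Compound 4 is `CS(=O)(=O)c1ccc(C(=O)N2CCC(C(=O)N3CCN(c4ccccc4)CC3)CC2)cc1[N+](=O)[O-]`. It differs from compound 1 by hydrogen in place of methyl on an aromatic carbon, or, one bond further out, 4-methylphenyl to phenyl. Within the data shown here, no step between measured compounds exists here. Because compound 1 and its two relatives all sit at the limit of > 60000 nM in this assay, at which 3 of the 3 values shown sit, no shift beyond the scatter is expected from this change. Compound 4 is expected at 100000 nM, within 30000 nM to 500000 nM, and most probably reported again only as a limit. The expected step that the limit leaves unreadable from compound 1 to compound 4 is estimated to lie within the scatter.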

Compound 4, half-maximal inhibitory concentration: > 60000 nM
Compound 4 was reported as a limit; the forecaster's own chance of this, stated with the estimate: 90%; the middle value does not contradict the limit.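

Compound 1 and compound 4 both return only limits, so no step can be read between them. The compounds shown leave open whether methyl or hydrogen on that aromatic carbon makes any difference in this assay.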